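One Methoxy Group Removed, Twice Over

The source may hold more compounds than are shown below. What is called first, only, known or untested is meant among the compounds shown, and "the series" means these compounds.

Compound 1 `COc1cc(-c2cc(/C=C/C(=O)c3ccc(N)cc3)[nH]n2)cc(OC)c1OC` gives > 100000 nM in a functional assay on SW-620 cells (Homo sapiens) for inhibition, read by sulforhodamine B assay, with a stated time of 48 h (a lower number here means that less compound is tolerated, a higher number that more compound is tolerated), which is a limit of the assay rather than a number.
Compound 2 `COc1ccc(-c2cc(/C=C/C(=O)c3ccc(N)cc3)[nH]n2)cc1OC` gives 82900 nM in this assay.
Compound 3 `COc1cc(C(=O)/C=C/c2cc(-c3cc(OC)c(OC)c(OC)c3)n[nH]2)cc(OC)c1OC` gives 5970 nM in this assay.

Compound 3 stands lowest of the two measured numbers, and its nearest neighbour, compound 2, sits well beyond the usual scatter above it. Compound 1 contributes only a limit, as stated in the limit of > 100000 nM in this assay, at which 1 of the 3 values shown sits.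

Compound 4 `COc1ccc(-c2cc(/C=C/C(=O)c3cc(OC)c(OC)c(OC)c3)[nH]n2)cc1OC` has not yet been measured. It differs from compound 3 by hydrogen in place of methoxy on an aromatic carbon. The very same change has already been made once among the measured compounds, from compound 1 to compound 2: hydrogen in place of methoxy on an aromatic carbon. The two changes share the same place word for word, so this is the same change, made on a different core. How the core of compound 3 differs from the core of compound 1 is not broken down here.

The measured step is an at least 1.2-fold lower number from compound 1 to compound 2 (0.08 log units; that floor lies within the scatter). Because compound 1 gives only the limit (the limit of > 100000 nM in this assay, at which 1 of the 3 values shown sits), the true size of that step cannot be pinned down; it is at least small, and it might be larger. Within the data shown here, compound 4 is therefore expected to lie close to compound 3, with the step of a 1.2-fold lower number from compound 3 to compound 4 (0.08 log units; within the scatter), kept small since the only known instance of this change, from compound 1 to compound 2, gave a floor within the scatter. The estimate for compound 4 is 5000 nM, expected to fall between 2000 nM and 15000 nM.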

Compound 4, concentration lethal to 50% of the cells: > 100000 nM
Compound 4 was reported as a limit; the forecaster's own chance of this, stated with the estimate: 5%; middle value at least 20-fold (1.30 log units) from the limit.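

Replacing a methoxy group with hydrogen did not behave the same way on the two cores in this assay: on the core of compound 3, the change gave an at least 16-fold higher number from compound 3 to compound 4 (1.22 log units; beyond the scatter), so the small step seen earlier could not simply be transferred to this core. Setting the two steps side by side shows that the core matters for this change, at least for these two pairs of compounds: the same change on two cores in this assay, an at least 1.2-fold lower number (0.08 log units; that floor lies within the scatter) from compound 1 to compound 2 and an at least 16-fold higher number (1.22 log units; beyond the scatter) from compound 3 to compound 4, at least 20-fold (1.30 log units) apart, beyond the scatter of two such steps

This does not show how large either step truly is, since each is only a bound set by a limit of the assay, and it does not explain why the two cores differ: the limit of > 100000 nM in this assay, at which 2 of the 4 values shown sit.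

With just two cores, the compounds shown leave open which of these two outcomes would be more typical on a further core in this series. They also leave open whether a hydroxyl group or a fluorine atom in the same place on the core of compound 3 would give a number close to that of compound 3 or, like hydrogen, one that reaches the limit of the assay.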